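Cutting the amine side group down from compound 3

The source may report more compounds than this note shows. Statements on the series, on what has been measured and on what is new or still open speak of the compounds shown alone.

In an ADME assay on microsomes from liver (Mus musculus) for metabolic stability, read by LC-MS, with a stated time of 10 min (a higher number here means that more of the compound is left, a lower number that less of the compound is left), compound 3 `FC1(F)CCC(CN(C[C@H]2Cc3c(cccc3N3CCNCC3)CN2)[C@H]2CCCc3cccnc32)CC1` gives 76.6% and ranks second of the three measured numbers. Compound 1 `c1cnc2c(c1)CCC[C@@H]2N(CC1CC1)C[C@H]1Cc2c(cccc2N2CCNCC2)CN1` stands higher at 88.3% and compound 2 `CN(C[C@H]1Cc2c(cccc2N2CCNC(C)(C)C2)CN1)[C@H]1CCCc2cccnc21` stands lowest at 44% on the same read-out. The next case is compound 4 `CCN(C[C@H]1Cc2c(cccc2N2CCNCC2)CN1)[C@H]1CCCc2cccnc21` and the change is methyl in place of 4,4-difluorocyclohexyl on a saturated chain carbon bound to an amine nitrogen which in words is methyl in place of 4,4-difluorocyclohexyl on a saturated chain carbon bound to an amine nitrogen. Going by the values given here, the only measured step at this place is a number 11.7 percentage points lower from compound 1 to compound 3 (beyond the scatter) and it is modest, though beyond the scatter. Among the compounds with values here, compound 2 differs from compound 3 in more than one place, so it gives no clean step, but compound 2 with its low 44% keeps the range open on the lower side. A small downward move is therefore expected, with a number 4.6 percentage points lower from compound 3 to compound 4 (within the scatter) as the estimated step and nothing beyond the scatter anticipated. The estimate for compound 4 is 72% with an expected range of 52% to 90% on this read-out.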

Compound 4, percent of the compound remaining: 53.8%
Compound 4: middle estimate off by 18.2 percentage points, on the high side, and the stated range covers the measured number.
By their numbers in this assay, from the lowest: compounds 2 and 4 (each within the scatter of the next); then compound 3; then compound 1.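

In this assay, the step of a number 22.8 percentage points lower from compound 3 to compound 4 (beyond the scatter) shows that this saturated chain carbon bound to an amine nitrogen tolerates the loss of 4,4-difluorocyclohexyl less well than the earlier step between the two ring-bearing groups suggested. The step of a number 34.5 percentage points lower from compound 1 to compound 4 (beyond the scatter) for methyl in place of cyclopropyl is larger still, so among these three compounds both ring-bearing groups leave more compound remaining than the ethyl end of compound 4, with cyclopropyl on top. No measured evidence on hand accounts for these drops.

From the compounds shown here alone, whether the ring itself matters or only the length of the group stays open, since an open chain such as propyl or isobutyl at this place would separate the two. A ring holding an ether oxygen, such as tetrahydropyranyl, would test whether the 4,4-difluorocyclohexyl result extends to other six-membered rings.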